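Dimethylamino in place of (4-chlorobenzyl)amino: compound 4

A few compounds are considered here, and "the series" means these few. Any claim that something is new, unique, unknown or untested is made for them only; others in the source may bear on it.

In a functional assay on HCT-15 cells (Homo sapiens) for inhibition, read by MTT assay, with a stated time of 72 h (a lower number here means a stronger inhibitor, a higher number a weaker inhibitor), compound 1 `COc1cc(Oc2cccc(Nc3ccccc3)c2)cc(OC)c1CNCc1ccccc1` gives 5020 nM, compound 2 `COc1cc(Oc2cccc(Nc3ccccc3)c2)cc(OC)c1CNCc1ccc(F)cc1` gives 3640 nM and compound 3 `COc1cc(Oc2cccc(Nc3ccccc3)c2)cc(OC)c1CNCc1ccc(Cl)cc1` gives 4850 nM. Compound 3 stands within the scatter of the other two: a 1.0-fold lower number from compound 1 to compound 3 (0.01 log units; within the scatter) and a 1.3-fold higher number from compound 2 to compound 3 (0.12 log units; within the scatter). Compound 4 `COc1cc(Oc2cccc(Nc3ccccc3)c2)cc(OC)c1CN(C)C` brings a different change: dimethylamino in place of (4-chlorobenzyl)amino on a saturated chain carbon bound to an aromatic carbon. The group leaves together with its ring. The measured steps, those two and a 1.4-fold lower number from compound 1 to compound 2 (0.14 log units; within the scatter), only exchange hydrogen, fluoro and chloro on an aromatic carbon, and all stay within the scatter. None of them tests this change, so they give only weak guidance. In this assay the expected step is a 1.0-fold higher number from compound 3 to compound 4 (0.01 log units; within the scatter), with no direction expected beyond the scatter. For compound 4 the estimate is 5000 nM, with an expected range of 1500 nM to 16000 nM.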

Compound 4, half-maximal inhibitory concentration: 15600 nM
Beside the measured number, compound 4's estimate is 3.1-fold (0.49 log units) below it; the range from low to high includes it.
By their numbers in this assay, from the lowest: compounds 2, 3 and 1 (each within the scatter of the next); then compound 4.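

In this assay, exchanging hydrogen, fluoro and chloro on the aromatic ring left the numbers within the scatter, whereas replacing the whole benzylamine-type group moves them beyond it: a 3.2-fold higher number from compound 3 to compound 4 (0.51 log units; beyond the scatter), a 4.3-fold higher number from compound 2 to compound 4 (0.63 log units; beyond the scatter) and a 3.1-fold higher number from compound 1 to compound 4 (0.49 log units; beyond the scatter). This position therefore responds to dimethylamino in place of all three benzylamine-type groups, with a modest step each time. Nothing available explains the step. Dimethylamino removes both the ring and the amine hydrogen, so their contributions remain unseparated. A methyl(benzyl)amino group or a plain methylamino group would pull them apart.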